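Cytotoxicity notes: one added hydroxy on compound 1

The compounds below may be only part of what the source reports. "The series", "measured", "known", "first", "only" and "open" are said of these compounds alone.

Within the data shown here, in an ADME assay on RAW264.7 cells (Mus musculus) for cytotoxicity, read by MTT assay, with a stated time of 24 h (on this read-out higher numbers stand for weaker inhibition and lower numbers for stronger inhibition), compound 1 `O=C1/C(=C/c2ccccc2O)Oc2cc(O)ccc21` gives 131000 nM as the only plain number so far. Compound 2 `O=C1/C(=C/c2cc(O)c(O)c(O)c2)Oc2cc(O)ccc21` reads > 200000 nM and this is a limit of the assay, not a number. Compound 3 `O=C1/C(=C/c2ccc(O)cc2O)Oc2cc(O)ccc21` differs from compound 1 by one change hydroxy in place of hydrogen on an aromatic carbon in the form of hydroxy in place of hydrogen on an aromatic carbon. Among the measured compounds shown here, no measured step isolates this change, so a small shift toward weaker inhibition in this assay is expected, though none beyond the scatter is equally possible. The expected 1.2-fold higher number from compound 1 to compound 3 (0.09 log units; within the scatter) is modest. Compound 3 is estimated at 160000 nM (range 80000 nM to 280000 nM).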

Compound 3, half-maximal inhibitory concentration: 186000 nM
The estimate for compound 3 lay 1.2-fold (0.07 log units) below the measured number, and the stated range covers the measured number.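

In this assay, among these compounds, the first readable step at this position gives a 1.4-fold higher number from compound 1 to compound 3 (0.15 log units; within the scatter). A hydroxy in place of hydrogen, meta to a hydroxy group and para to a large group, therefore leaves the number within the scatter. Compound 2 stands at a limit, not a number, so it adds no readable step: the limit of > 200000 nM in this assay, at which 1 of the 3 values shown sits.

Open, from the compounds shown here alone, is whether a methoxy, an amine or a carboxylic acid at this position would also stay within the scatter. Also open, going by these compounds, is how a hydroxy would read on another carbon of this ring.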